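Piperazine-bearing crotonamide expected close to its methyl parent

This account rests on a few compounds, and the source may have more. Where it says the series, first, only, none or still open, it means among the compounds named here.

Compound 1 `CC/C=C/C(=O)Nc1cc2c(N3CCc4ccccc43)ncnc2cc1OC`: 5890 nM
Compound 2 `CC(C)=CC(=O)Nc1cc2c(N3CCc4ccccc43)ncnc2cc1O[C@@H]1CCOC1`: 4620 nM
Compound 3 `CC/C=C/C(=O)Nc1cc2c(N3CCc4ccccc43)ncnc2cc1O[C@@H]1CCOC1`: 9590 nM

In a functional assay on PC-3 cells (Homo sapiens) for antiproliferative activity, read by MTT assay, with a stated time of 72 h (on this read-out lower numbers stand for stronger inhibition and higher numbers for weaker inhibition), compound 1 gives 5890 nM, the second highest of the three numbers; compound 2 and compound 3 both lie within the scatter of it, as the step of a 1.6-fold higher number from compound 1 to compound 3 (0.21 log units; within the scatter) illustrates. Compound 4 `COc1cc2ncnc(N3CCc4ccccc43)c2cc1NC(=O)/C=C/CN1CCN(C)CC1` differs from compound 1 by 4-methylpiperazin-1-yl in place of methyl on a saturated chain carbon bound to a double-bonded chain carbon. Within the data shown here, no measured step covers this particular change. Among the measured compounds shown here, the one step on the chain attached to the carbonyl, a 2.1-fold higher number from compound 2 to compound 3 (0.32 log units; beyond the scatter), was modest, so a change placed further out along that chain is expected to shift the number little: the expected step is a 1.3-fold lower number from compound 1 to compound 4 (0.12 log units; within the scatter), with no direction beyond the scatter. Compound 4 is therefore estimated at 4500 nM, with a range from 1500 nM to 14000 nM.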

Compound 4, half-maximal inhibitory concentration: 9180 nM
Estimate against measurement, compound 4: 2.0-fold (0.31 log units) below; the measured number falls inside the stated range.
By their numbers in this assay, from the lowest: compounds 2, 1, 4 and 3 (each within the scatter of the next, the first and the last beyond it).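

Putting 4-methylpiperazin-1-yl in place of methyl on a saturated chain carbon bound to a double-bonded chain carbon gives a 1.6-fold higher number from compound 1 to compound 4 (0.19 log units; within the scatter) in this assay. This place on the chain therefore accepts a much larger group, one carrying a six-membered non-aromatic ring, without a change beyond the scatter. Nothing available explains this result.

From the compounds shown here alone, whether dimethylamino or morpholin-4-yl at this place would read the same stays open. So does the effect of the 4-methylpiperazin-1-yl group alongside the oxolan-3-yl group of compound 3.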